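Ethyl on the Amide Nitrogen: No Shift Expected

The compounds below may be only part of what the source reports. "The series", "measured", "known", "first", "only" and "open" are said of these compounds alone.

Compound 1 `CC(=O)C1=C(C)NC(=O)NC1c1ccsc1` gives 1% in an assay on membranes from HeLa cells for displacement of a labelled ligand from adenosine receptor A3 (Homo sapiens), read by scintillation counting, with a stated time of 180 min, tested at 1 uM; a lower number here means less inhibition, a higher number more inhibition at the concentration tested (going by the name of the read-out); compound 2 `CC1=C(C(N)=O)C(c2ccsc2)NC(=O)N1` gives 1% in this assay.

Compound 2 stands level with compound 1 at the digits shown, the step of no change at the digits printed from compound 1 to compound 2 (within the scatter) lying within the scatter. Compound 3 `CCNC(=O)C1=C(C)NC(=O)NC1c1ccsc1` differs from compound 2 by ethyl in place of hydrogen on an amide-type nitrogen. For the measured compounds named here, no measured step touches this amide nitrogen, and the only step known, from compound 1 to compound 2, was flat. He therefore expects no step beyond the scatter, a number 1 percentage points higher from compound 2 to compound 3 (within the scatter), and estimates compound 3 at 2% in this assay, within -8% to 12%.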

Compound 3, a percentage reported as inhibition, at one concentration (the size of the read-out at that concentration, not a potency): 1%
Estimate against measurement, compound 3: 1 percentage points above; the measured number falls inside the stated range.
By their numbers in this assay, from the lowest: compounds 1, 2 and 3 (each within the scatter of the next).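

In this assay, for the compounds shown here, ethyl on the amide nitrogen gives no change at the digits printed from compound 2 to compound 3 (within the scatter), the first reading at this nitrogen, and ethylamino in place of methyl on the carbonyl carbon gives no change at the digits printed from compound 1 to compound 3 (within the scatter). Methyl, amino and ethylamino on that carbonyl carbon thus read alike at the concentration tested. From the compounds shown here alone, whether a longer chain such as butyl on the amide nitrogen, or a carboxylic acid on the carbonyl carbon, would read differently in this assay stays open. No evidence is at hand that bears on this result.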